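A Piperidine Amine Returns to the Sulfonamide Core

A few compounds are considered here, and "the series" means these few. Any claim that something is new, unique, unknown or untested is made for them only; others in the source may bear on it.

Of the compounds shown here, three on a shared sulfonamide core have been measured. Compound 1 `Cc1cc(C)c(S(=O)(=O)N2CCC(N3CCC(C)CC3)CC2)c(C)c1` gives in a functional assay on DLD-1 cells (Homo sapiens) for antiproliferative activity, read by CellTiter-Glo, with a stated time of 72 h (a higher number here means a weaker inhibitor, a lower number a stronger inhibitor), a value of 0.03 nM. Compound 2 `Cc1ccc(C2CCN(S(=O)(=O)c3c(C)cc(C)cc3C)CC2)cc1` gives in this assay a value of 2200 nM. Compound 3 `Cc1cc(C)c(S(=O)(=O)N2CCC(N3CCCCCC3)CC2)c(C)c1` gives in this assay a value of 5.3 nM. Compound 3 therefore stands second highest of the three numbers: its nearest neighbour is compound 1, reached by a 180-fold higher number from compound 1 to compound 3 (2.25 log units; beyond the scatter), and its furthest is compound 2, reached by a 420-fold lower number from compound 2 to compound 3 (2.62 log units; beyond the scatter).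

Compound 4 `Cc1cc(C)c(S(=O)(=O)N2CCC(N3CCC(C(C)C)CC3)CC2)c(C)c1` has not yet been measured. The change from compound 3 is 4-isopropylpiperidin-1-yl in place of azepan-1-yl on a saturated ring carbon. The step that bears on this is a 180-fold higher number from compound 1 to compound 3 (2.25 log units; beyond the scatter), which ran the other way between a 4-methylpiperidin-1-yl group and the azepan-1-yl group now leaving; a 73000-fold higher number from compound 1 to compound 2 (4.87 log units; beyond the scatter) shows the same position is sensitive to what it carries. Since compound 4 brings back a piperidine with a larger substituent, a large step toward a lower number is expected in this assay, estimated as an 18-fold lower number from compound 3 to compound 4 (1.25 log units; beyond the scatter), though whether it fully reaches the level of compound 1 is uncertain. Compound 4 is therefore expected to give about 0.3 nM, within a range from 0.02 nM to 5 nM.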

Compound 4, half-maximal inhibitory concentration: 0.3 nM
Estimate against measurement, compound 4: no gap at the digits printed; the measured number falls inside the stated range.
By their numbers in this assay, from the lowest: compound 1; then compound 4; then compound 3; then compound 2.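

Compound 4 shows that the gain over the other two groups does not belong to the 4-methylpiperidin-1-yl group alone: in this assay, a second substituted piperidine gives an 18-fold lower number from compound 3 to compound 4 (1.25 log units; beyond the scatter) and a 7300-fold lower number from compound 2 to compound 4 (3.87 log units; beyond the scatter). It also gives the first view of a change made on the piperidine itself rather than a replacement of the whole group. With the ring kept and isopropyl in place of methyl, there is a 10-fold higher number from compound 1 to compound 4 (1.00 log units; beyond the scatter), so the position responds to the substituent on the piperidine as well as to the ring that carries it, and this step is still beyond the usual scatter. Nothing shown accounts for why either substituent gives the number it does.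

As far as these compounds go, with only methyl and isopropyl on the piperidine, two points cannot establish a trend with substituent size, so it remains open whether a tert-butyl group would continue in the same direction. The compounds also leave open how a piperidin-1-yl group with no substituent, or one carrying a hydroxyl group in place of the isopropyl, would stand in this assay.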